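Aryl ketone variation on the shared core, cytotoxicity

The compounds below may be only part of what the source reports. "The series", "measured", "known", "first", "only" and "open" are said of these compounds alone.

The series shares the core of compound 1 `COc1cc(-c2nnc3n2NC(c2cccs2)C(C(=O)c2ccccc2)S3)cc(OC)c1OC` and varies the aromatic group on the carbonyl carbon and the group on the saturated ring carbon. In a functional assay on HepG2 cells (Homo sapiens) for cytotoxicity, read by MTT assay, with a stated time of 48 h (on this read-out higher numbers stand for weaker inhibition and lower numbers for stronger inhibition), compound 1 gives only a limit, > 100000 nM. That reading is the limit of > 100000 nM in this assay, at which 1 of the 3 values shown sits. Compound 3 `COc1cc(-c2nnc3n2NC(c2cccs2)C(C(=O)c2ccc(Cl)cc2)S3)cc(OC)c1OC` gives 13200 nM in this assay. Compound 2 `COc1cc(-c2nnc3n2NC(c2ccco2)C(C(=O)c2cccs2)S3)cc(OC)c1OC` gives 64100 nM in this assay; of the two plain numbers this is the higher one, with compound 3 below it beyond the scatter. Among the measured compounds shown here, the one measured step in the set is an at least 7.5-fold lower number from compound 1 to compound 3 (0.87 log units; beyond the scatter), a change on the aromatic group attached to the carbonyl carbon.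

Compound 4 `COc1cc(-c2nnc3n2NC(c2ccco2)C(C(=O)c2cccc4ccccc24)S3)cc(OC)c1OC` is not yet measured. It differs from compound 2 by naphthalen-1-yl in place of thiophen-2-yl on a carbonyl carbon. The step from compound 1 to compound 3 bears on this, as it also alters the aromatic group on the carbonyl carbon, and it lowered the number beyond the scatter. The change to compound 4 is of a different kind, so the direction is less certain, but a lowering is taken as the more likely reading, expected as a 2.6-fold lower number from compound 2 to compound 4 (0.41 log units; beyond the scatter). Compound 4 is therefore expected at 25000 nM in this assay, within a range of 8000 nM to 80000 nM.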

Compound 4, half-maximal inhibitory concentration: 33900 nM
Compound 4: the middle estimate sits 1.4-fold (0.13 log units) below what was measured; the range from low to high includes it.
By their numbers in this assay, from the lowest: compound 3; then compounds 4 and 2 (each within the scatter of the next). At a limit, above all of these: compound 1.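

In this assay, naphthalen-1-yl in place of thiophen-2-yl on the carbonyl carbon gives a 1.9-fold lower number from compound 2 to compound 4 (0.28 log units; within the scatter), so compound 2 and compound 4 cannot be told apart on this read-out. With the group on the saturated ring carbon held constant, this position accepts 2 six-membered aromatic rings of carbon only in place of one five-membered aromatic ring with 1 hetero atom, without a reading beyond the scatter. The earlier step on the same carbonyl-bound aromatic group, an at least 7.5-fold lower number from compound 1 to compound 3 (0.87 log units; beyond the scatter), did pass beyond the scatter, so a change at this position does not always register, and that step starts from a value that is only a limit: the limit of > 100000 nM in this assay, at which 1 of the 4 values shown sits.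

The compounds shown leave open how this position responds to a group other than an aromatic ring, such as a cyclohexyl group, a longer alkyl chain, or a phenyl ring carrying a carboxylic acid or an amine. Among the compounds shown here, they also leave open whether the chloro step would hold with the other group on the saturated ring carbon, as no pair here isolates a change at that carbon.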